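Swapping the Group on a Sulfonyl Sulfur

The compounds below may be only part of what the source reports. "The series", "measured", "known", "first", "only" and "open" are said of these compounds alone.

Compound 1 (`Cn1c(=O)c(S(=O)(=O)Nc2ccc(F)cc2)cc2cnc(Nc3ccc4[nH]ccc4c3)nc21`) and compound 2 (`Cn1c(=O)c(S(=O)(=O)Nc2ccc(F)cc2F)cc2cnc(Nc3ccc4[nH]ccc4c3)nc21`) share one core. In a functional assay on DU-145 cells (Homo sapiens) for inhibition, read by trypan blue exclusion, with a stated time of 72 h (a lower number here means a stronger inhibitor, a higher number a weaker inhibitor), compound 1 gives 5000 nM and compound 2 gives 5000 nM, so compound 2 stands level with compound 1. Fluoro in place of hydrogen on an aromatic carbon gave no change at the digits printed from compound 1 to compound 2 (within the scatter). Compound 3 (`Cn1c(=O)c(S(=O)(=O)c2ccc([N+](=O)[O-])cc2F)cc2cnc(Nc3ccc4[nH]ccc4c3)nc21`) carries 2-fluoro-4-nitrophenyl in place of (2,4-difluorophenyl)amino on a sulfonyl sulfur. Among the measured compounds shown here, the only measured step is far smaller than this swap, so it offers weak guidance and favours no direction. The expected step is no change at the digits printed from compound 2 to compound 3 (within the scatter), none beyond the scatter in this assay. Compound 3 is estimated at 5000 nM, with an expected range of 1000 nM to 20000 nM.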

Compound 3, half-maximal inhibitory concentration: 400 nM
Compound 3: the middle estimate sits 13-fold (1.10 log units) above what was measured; measured number below the stated range.
By their numbers in this assay, from the lowest: compound 3; then compounds 1 and 2 (each within the scatter of the next).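

On the sulfonyl sulfur, this assay responds strongly to the group: 2-fluoro-4-nitrophenyl in place of (2,4-difluorophenyl)amino gives a 13-fold lower number from compound 2 to compound 3 (1.10 log units; beyond the scatter), and in place of (4-fluorophenyl)amino it gives a 13-fold lower number from compound 1 to compound 3 (1.10 log units; beyond the scatter). The added fluoro alone had moved nothing beyond the scatter, so this position can respond far more to a swap of the whole group. No measurement here accounts for the drop. The compounds shown leave open whether losing the amino link or gaining the nitro group carries the step. A 2,4-difluorophenyl group on the sulfur, or an amine where the nitro group stands, would help separate the two.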